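Cyclohexyl for Methyl on a Long-Chain Compound

The source may hold more compounds than are shown below. What is called first, only, known or untested is meant among the compounds shown, and "the series" means these compounds.

In a functional assay on brain (Rattus norvegicus, strain Wistar) for inhibition (on this read-out lower numbers stand for stronger inhibition and higher numbers for weaker inhibition), compound 1 (`CCCCCCCCCCOc1ccc(-c2c(C)[nH]c(=O)n2C)cc1`) gives 6900 nM and compound 2 (`CCCCCCCCCCCOc1ccc(-c2c(C)[nH]c(=O)n2C)cc1`) gives 9700 nM, and the step of a 1.4-fold higher number from compound 1 to compound 2 (0.15 log units; within the scatter) lies within the scatter. Compound 3 (`CCCCCCCCCCCCCCCCCCOc1ccc(-c2c(C)[nH]c(=O)n2C)cc1`) reads > 100000 nM, which is a limit of the assay and not a number. Its saturated chain is the only place where it differs from the other two, and the steps of an at least 14-fold higher number from compound 1 to compound 3 (1.16 log units; beyond the scatter) and an at least 10-fold higher number from compound 2 to compound 3 (1.01 log units; beyond the scatter) are both large, towards weaker inhibition.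

Compound 4 (`CCCCCCCCCCCCCCCCCCOc1ccc(-c2c(C)[nH]c(=O)n2C2CCCCC2)cc1`) keeps that chain and changes elsewhere: cyclohexyl in place of methyl on an aromatic nitrogen. For the measured compounds named here, none of the measured steps touches this nitrogen, so they give no size for the change itself. They bear only on the chain, which stays as it was in compound 3, and weak inhibition is therefore expected to persist, with no clear recovery in this assay. The expected step is a number no higher from compound 3 to compound 4 (the limit leaves the size open), and another reading at the limit is quite possible. For compound 4 the estimated value is 100000 nM, with an expected range from 20000 nM to 500000 nM.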

Compound 4, half-maximal inhibitory concentration: > 100000 nM
Compound 4 was reported as a limit (the forecaster's own chance of this, stated with the estimate: 65%); the middle value lies on the limit itself.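

No step can be read from compound 3 to compound 4 because both values are limits of the assay and not numbers: the limit of > 100000 nM in this assay, at which 2 of the 4 values shown sit.

The compounds shown leave open whether cyclohexyl in place of methyl on an aromatic nitrogen changes inhibition at all, and in which direction.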